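Swapping a Triazole Tail for Methoxy

The source may hold more compounds than are shown below. What is called first, only, known or untested is meant among the compounds shown, and "the series" means these compounds.

Compound 1 `Cn1ncc(Cl)c1-c1cc(C(=O)N[C@@H]2CN[C@H](CCn3cncn3)C[C@H]2c2ccc(Cl)c(Cl)c2)oc1Cl` is the anchor here: in an assay for inhibition of RAC-alpha serine/threonine-protein kinase (Homo sapiens), read by HTRF, with a stated time of 1 h (a lower number here means a stronger inhibitor, a higher number a weaker inhibitor), compound 1 gives 4.47 nM, the only firm number shown. Compound 2 `O=C(N[C@@H]1CNCC[C@H]1c1ccc(Cl)cc1)c1ccc(-c2ncnc3c2CCC3O)s1` returns only a limit in this assay, > 1000 nM, so it offers no number to compare. Compound 3 `COCC[C@@H]1C[C@@H](c2ccc(Cl)c(Cl)c2)[C@H](NC(=O)c2cc(-c3c(Cl)cnn3C)c(Cl)o2)CN1` differs from compound 1 in one place: methoxy in place of 1H-1,2,4-triazol-1-yl on a saturated chain carbon, two bonds along the chain from a saturated ring carbon. Within the data shown here, with no measured step to lean on, a modest loss seems the likeliest outcome, and the expected step from compound 1 to compound 3 is a 2.0-fold higher number from compound 1 to compound 3 (0.30 log units; within the scatter). Compound 3 is therefore estimated at 9 nM in this assay, with a range from 2.5 nM to 35 nM.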

Compound 3, half-maximal inhibitory concentration: 7.01 nM
Compound 3: the middle estimate sits 1.3-fold (0.11 log units) above what was measured, within the range that was stated.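

On this saturated chain, methoxy can take the place of 1H-1,2,4-triazol-1-yl: in this assay the swap gives a 1.6-fold higher number from compound 1 to compound 3 (0.20 log units; within the scatter) and so leaves the reading within the scatter. For this pair, then, the five-membered aromatic ring at the end of the chain is not needed to keep a low number in this assay.

From the compounds shown here alone, whether an amine, a carboxylic acid or a longer chain at the same place would read alike stays open. Nothing shown explains why the two groups give such similar numbers.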